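Piperidine for Pyrrolidine: What Compound 4 Might Gain

The compounds below may be only part of what the source reports. "The series", "measured", "known", "first", "only" and "open" are said of these compounds alone.

Four compounds share one core and differ in two places. Compound 1 `O=C(CN1CCCC1)Nc1ccc2ncnc(Nc3cccc(Cl)c3)c2c1` carries a pyrrolidin-1-yl group and a 3-chlorophenyl group. In a functional assay on HepG2 cells (Homo sapiens) for antiproliferative activity, read by MTT assay, with a stated time of 48 h (a lower number here means a stronger inhibitor, a higher number a weaker inhibitor), compound 1 gives > 100000 nM, which is a limit of the assay rather than a number. Compound 2 `O=C(CN1CCCCC1)Nc1ccc2ncnc(Nc3cccc(Cl)c3)c2c1` differs by piperidin-1-yl in place of pyrrolidin-1-yl on a saturated chain carbon bound to a carbonyl carbon; in this assay compound 2 gives 12000 nM, a step of an at least 8.3-fold lower number from compound 1 to compound 2 (0.92 log units; beyond the scatter). Compound 3 `O=C(CN1CCCC1)Nc1ccc2ncnc(Nc3ccc(Cl)cc3)c2c1` differs from compound 1 by 4-chlorophenyl in place of 3-chlorophenyl on a nitrogen on an aromatic ring, and in this assay compound 3 gives 18000 nM, a step of an at least 5.5-fold lower number from compound 1 to compound 3 (0.74 log units; beyond the scatter). The values of compound 2 and compound 3 lie within the scatter of each other. Compound 4 `O=C(CN1CCCCC1)Nc1ccc2ncnc(Nc3ccc(Cl)cc3)c2c1` is unmeasured; it differs from compound 3 by piperidin-1-yl in place of pyrrolidin-1-yl on a saturated chain carbon bound to a carbonyl carbon, the same change as from compound 1 to compound 2, at the same place. That earlier step is only a lower bound because compound 1 sits at the limit of > 100000 nM in this assay, at which 1 of the 3 values shown sits. For compound 4 a smaller step is expected, a 3.6-fold lower number from compound 3 to compound 4 (0.56 log units; beyond the scatter). Compound 4 is estimated at 5000 nM in this assay, between 1500 nM and 15000 nM.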

Compound 4, half-maximal inhibitory concentration: 16000 nM
Estimate against measurement, compound 4: 3.2-fold (0.51 log units) below; the whole stated range lies below it.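

In this assay piperidin-1-yl in place of pyrrolidin-1-yl gives a 1.1-fold lower number from compound 3 to compound 4 (0.05 log units; within the scatter) and so does not repeat the earlier step on the core of compound 3: the same change on two cores in this assay, an at least 8.3-fold lower number (0.92 log units; beyond the scatter) from compound 1 to compound 2 and a 1.1-fold lower number (0.05 log units; within the scatter) from compound 3 to compound 4, at least 7.4-fold (0.86 log units) apart, beyond the scatter of two such steps. The change to 4-chlorophenyl gives a 1.3-fold higher number from compound 2 to compound 4 (0.12 log units; within the scatter) and likewise does not carry over between cores: the same change on two cores in this assay, an at least 5.5-fold lower number (0.74 log units; beyond the scatter) from compound 1 to compound 3 and a 1.3-fold higher number (0.12 log units; within the scatter) from compound 2 to compound 4, at least 7.4-fold (0.86 log units) apart, beyond the scatter of two such steps. Compound 1 stands at a limit rather than a number, so the true size of neither earlier step is shown, and four compounds set no rule beyond themselves: the limit of > 100000 nM in this assay, at which 1 of the 4 values shown sits.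

The compounds shown leave open whether other amines on the chain, such as morpholin-4-yl or azepan-1-yl, or a longer chain would behave the same way. They also leave open how 3-bromophenyl or 4-bromophenyl would pair with each amine.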